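Imidazolyl and thiadiazolyl thioethers of the shared core

The source may report more compounds than this note shows. Statements on the series, on what has been measured and on what is new or still open speak of the compounds shown alone.

Two members of the series have been tested in a functional assay on Jurkat cells (Homo sapiens) for inhibition (a lower number here means a stronger inhibitor, a higher number a weaker inhibitor), and neither gave a number. Compound 1 `CC(C)[C@H](NC(=O)COc1cccc2ccccc12)C(=O)N[C@@H](CC(=O)O)C(=O)CSc1ncc[nH]1` reaches only the limit of the assay, > 200000 nM. Compound 2 `CC(C)[C@H](NC(=O)COc1cccc2ccccc12)C(=O)N[C@@H](CC(=O)O)C(=O)CSc1nc(-c2ccccc2)c(-c2ccccc2)o1`, with a diphenyl-substituted oxazole in place of the imidazole, likewise stops at the limit, > 200000 nM. So both values shown sit at the limit of > 200000 nM in this assay, at which 2 of the 2 values shown sit, and compound 1 stands nowhere on a numerical scale; it is simply inactive up to the concentration tested.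

Compound 3 `Cc1nnc(SCC(=O)[C@H](CC(=O)O)NC(=O)[C@@H](NC(=O)COc2cccc3ccccc23)C(C)C)s1` changes compound 1 by 5-methyl-1,3,4-thiadiazol-2-yl in place of 1H-imidazol-2-yl on a sulfur. Within the data shown here, no measured step exists between this pair, and the two measured compounds, differing far more widely in the ring on that sulfur, both sit at the limit. No step beyond the scatter is expected from compound 1 to compound 3 in this assay, and a value at or above the limit is the likely outcome; compound 3 is estimated at 300000 nM, within 100000 nM to 1000000 nM, which means an expected step that the limit leaves unreadable from compound 1 to compound 3.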

Compound 3, half-maximal inhibitory concentration: 190000 nM
Estimate against measurement, compound 3: 1.6-fold (0.20 log units) above; measured number inside the range.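

In this assay compound 3 gives 190000 nM, the only number among the compounds shown. The change reads as an at least 1.0-fold lower number from compound 1 to compound 3 (0.02 log units; that floor lies within the scatter), so no gain beyond the scatter can be claimed, though the true step may be larger. Only a floor can be given because the value of compound 1 is a limit and not a number: the limit of > 200000 nM in this assay, at which 2 of the 3 values shown sit.

The compounds shown leave open whether any ring on this sulfur can give a value well clear of the limit. They also leave open whether the methyl group of the thiadiazole contributes, which 5-amino-1,3,4-thiadiazol-2-yl or the unsubstituted 1,3,4-thiadiazol-2-yl in its place would test.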